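Replacing the diethylamino group of compound 3

The compounds below may be only part of what the source reports. "The series", "measured", "known", "first", "only" and "open" are said of these compounds alone.

In a functional assay on L5178Y cells (Mus musculus) for inhibition, read by MTT assay, with a stated time of 24 h (on this read-out higher numbers stand for weaker inhibition and lower numbers for stronger inhibition), compound 1 `COc1cc(O)c2c(c1)O[C@H](c1ccc(O)cc1)C/C2=N\Nc1ccccc1` gives >= 11300 nM, which is a limit of the assay. Compound 2 `COc1cc(O)c2c(c1)O[C@H](c1ccc(OCC3CO3)cc1)CC2=O` gives >= 11300 nM, also a limit. Compound 3 `CCN(CC)CC(O)COc1ccc([C@@H]2CC(=O)c3c(O)cc(OC)cc3O2)cc1` gives >= 11300 nM, again only a limit. All three values shown rest on (the limit of >= 11300 nM in this assay, at which 3 of the 3 values shown sit). Compound 4 `COC(=O)C1CCN(CC(O)COc2ccc([C@@H]3CC(=O)c4c(O)cc(OC)cc4O3)cc2)CC1` carries 4-(methoxycarbonyl)piperidin-1-yl in place of diethylamino, on a saturated chain carbon, two bonds along the chain from an oxygen on a saturated carbon: 4-(methoxycarbonyl)piperidin-1-yl in place of diethylamino on a saturated chain carbon, two bonds along the chain from an oxygen on a saturated carbon. For the measured compounds named here, the only measured step bearing on this change, a step that the two limits leave unreadable from compound 2 to compound 3, offers no size to carry over. The expected step in this assay is therefore a step that the limit leaves unreadable from compound 3 to compound 4, with none beyond the scatter foreseen and no direction expected. For compound 4 the estimate is 15000 nM, with an expected range from 6000 nM to 40000 nM.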

Compound 4, half-maximal inhibitory concentration: >= 11300 nM
Compound 4: a limit, no number; the forecaster's own chance of this, stated with the estimate: 65%; the middle value does not contradict the limit.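

For the compounds shown here, no step from compound 3 to compound 4 can be read, since both values are only limits: the limit of >= 11300 nM in this assay, at which 4 of the 4 values shown sit. The compounds shown leave open how strongly any of them inhibits, and whether exchanging diethylamino for 4-(methoxycarbonyl)piperidin-1-yl matters at all.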